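Working notes on a three-compound cytotoxicity series

The source may report more compounds than this note shows. Statements on the series, on what has been measured and on what is new or still open speak of the compounds shown alone.

Compound 1 `O=[N+]([O-])c1ccc2nc(CNc3ccccc3)cnc2c1`: 56000 nM
Compound 2 `Cc1cccc(NCc2cnc3cc([N+](=O)[O-])ccc3n2)c1`: 77000 nM

Among the compounds with values here, in a functional assay on PC-3 cells (Homo sapiens) for cytotoxicity, read by MTT assay, with a stated time of 96 h (a higher number here means a weaker inhibitor, a lower number a stronger inhibitor), compound 1 gives 56000 nM and compound 2 gives 77000 nM; the single measured step, a 1.4-fold higher number from compound 1 to compound 2 (0.14 log units; within the scatter), leaves the two within the scatter of each other, so compound 2 is not distinguished from compound 1 on these numbers. Compound 3 `O=[N+]([O-])c1ccc2nc(CNc3ccc(Cl)cc3)cnc2c1` differs from compound 2 by 4-chlorophenyl in place of 3-methylphenyl on an amine nitrogen. Within the data shown here, no measured step involves a chlorine, so nothing bears directly on this change; the one known step was within the scatter. The step of a 1.1-fold lower number from compound 2 to compound 3 (0.04 log units; within the scatter) is therefore expected to stay within the scatter. Compound 3 is estimated at 70000 nM, between 25000 nM and 200000 nM.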

Compound 3, half-maximal inhibitory concentration: 70000 nM
Beside the measured number, compound 3's estimate shows no gap at the digits printed, and the stated range covers the measured number.
By their numbers in this assay, from the lowest: compounds 1, 3 and 2 (each within the scatter of the next).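

In this assay, within the data shown here, adding a chloro group gives a 1.3-fold higher number from compound 1 to compound 3 (0.10 log units; within the scatter), the first chlorine step. The change of 3-methylphenyl to 4-chlorophenyl on an amine nitrogen gives a 1.1-fold lower number from compound 2 to compound 3 (0.04 log units; within the scatter), so the hydrogen, methyl and chloro forms are not distinguished on these numbers. On these data alone, whether a carboxylic acid or an amine on that aromatic ring would give a step beyond the scatter remains open. No evidence is available to explain these close values.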